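The source may report more compounds than this note shows. Statements on the series, on what has been measured and on what is new or still open speak of the compounds shown alone.

Measured so far in an in vitro ADME assay on microsomes from liver (Homo sapiens) for metabolic stability, using NADPH (on this read-out higher numbers stand for fast clearance and lower numbers for slow clearance), are these
compound 1 `CC(O)CCNC(=O)c1cc2cc(C#N)ccc2n1Cc1cccc(OC(F)(F)F)c1` gives 113 mL.min-1.g-1
compound 2 `N#Cc1ccc2c(c1)cc(C(=O)NCCC(O)C(F)(F)F)n2Cc1cccc(OC(F)(F)F)c1` gives 59 mL.min-1.g-1

Among the measured compounds shown here, compound 2 lies within the scatter of compound 1, the only other compound measured, so the two cannot be told apart. Compound 3 `CC(O)C1(CNC(=O)c2cc3cc(C#N)ccc3n2Cc2cccc(OC(F)(F)F)c2)CCCC1` differs from compound 2 by one change (a group of 8 heavy atoms (7 carbon, 1 oxygen; one five-membered non-aromatic ring of carbon only) in place of a group of 7 heavy atoms (3 carbon, 1 oxygen, 3 fluorine; no ring), on a saturated chain carbon bound to an amide-type nitrogen). For the measured compounds named here, one measured step bears on it (a 1.9-fold lower number from compound 1 to compound 2 (0.28 log units; within the scatter)), and that step is within the scatter. The entering group has no fluorine, and neither has compound 1 (113 mL.min-1.g-1), so a number close to that one is expected. The expected change is modest (a 1.9-fold higher number from compound 2 to compound 3 (0.27 log units; within the scatter)). For compound 3 the estimated value is 110 mL.min-1.g-1 (expected range 50 mL.min-1.g-1 to 260 mL.min-1.g-1).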

Compound 3, intrinsic clearance in microsomes: 505 mL.min-1.g-1
The estimate for compound 3 lay 4.6-fold (0.66 log units) below the measured number, and the stated range ends below it.
By their numbers in this assay, from the lowest: compounds 2 and 1 (each within the scatter of the next); then compound 3.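

In this assay, the group on this saturated chain carbon bound to an amide-type nitrogen can shift clearance well beyond the scatter: the group with the five-membered carbon ring gives an 8.6-fold higher number from compound 2 to compound 3 (0.93 log units; beyond the scatter) and also a 4.5-fold higher number from compound 1 to compound 3 (0.65 log units; beyond the scatter). Compound 1 has no fluorine either, so the lack of fluorine alone does not set compound 3 apart. No measurement here accounts for the rise.

On these data alone, whether the ring itself matters remains open. Compounds with two methyl groups in place of the ring, or with trifluoromethyl in place of the methyl of compound 3, would test this.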